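Methoxy Replaces Fluorine on the Benzyl Arm

The source may report more compounds than this note shows. Statements on the series, on what has been measured and on what is new or still open speak of the compounds shown alone.

Of the compounds shown here, three sharing one core have been measured in a functional assay on KM12 cells (Homo sapiens) for inhibition, read by sulforhodamine B assay, with a stated time of 48 h; a higher number here means a weaker inhibitor of growth, a lower number a stronger inhibitor of growth. Compound 1 `Nc1cc(N)c2nc(-c3ccccc3)c(NCc3ccc(Cl)c(Cl)c3)nc2c1` gives 21400 nM, compound 2 `COc1ccc(CNc2nc3cc(N)cc(N)c3nc2-c2ccccc2)cc1OC` gives 30900 nM, and compound 3 `Nc1cc(N)c2nc(-c3ccccc3)c(NCc3ccc(F)cc3)nc2c1` gives 7410 nM. Compound 3 thus shows the lowest number of the three: the step of a 2.9-fold lower number from compound 1 to compound 3 (0.46 log units; beyond the scatter) and the step of a 4.2-fold lower number from compound 2 to compound 3 (0.62 log units; beyond the scatter) both lie beyond the scatter, while the step of a 1.4-fold higher number from compound 1 to compound 2 (0.16 log units; within the scatter) does not.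

Compound 4 `COc1ccc(CNc2nc3cc(N)cc(N)c3nc2-c2ccccc2)cc1` differs from compound 3 in one place: methoxy in place of fluoro on an aromatic carbon. Within the data shown here, no measured step makes exactly this change. The closest is a 4.2-fold lower number from compound 2 to compound 3 (0.62 log units; beyond the scatter), where two methoxy groups gave way to a single fluorine and the number fell. Compound 4 keeps one methoxy group and loses the fluorine, so part of that movement is expected to reverse, giving a modest rise in this assay, estimated as a 2.0-fold higher number from compound 3 to compound 4 (0.31 log units; beyond the scatter). Compound 4 is therefore expected at 15000 nM, within a range from 6000 nM to 40000 nM.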

Compound 4, concentration for total growth inhibition: 26300 nM
Compound 4: middle estimate off by 1.8-fold (0.24 log units), on the low side; the range from low to high includes it.
By their numbers in this assay, from the lowest: compound 3; then compounds 1, 4 and 2 (each within the scatter of the next).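

In this assay, among these compounds, the single swap of fluoro for methoxy is enough on its own to raise the number (a 3.5-fold higher number from compound 3 to compound 4 (0.55 log units; beyond the scatter)), so one methoxy group at this place loses what compound 3 gains. A second methoxy group makes no difference that stands out from the scatter (a 1.2-fold lower number from compound 2 to compound 4 (0.07 log units; within the scatter)), and the 4-methoxyphenyl and 3,4-dichlorophenyl arms likewise cannot be told apart (a 1.2-fold higher number from compound 1 to compound 4 (0.09 log units; within the scatter)). Nothing shown gives a reason why fluoro stands apart.

Going by these compounds, whether the low number belongs to fluoro itself remains open, since only fluoro, methoxy and the dichloro pattern appear on this ring. Plain hydrogen, a single chlorine, an amine or a carboxylic acid at this same place would show how narrow that preference is.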